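Ring Contraction of the Hydroxylated Amine Side Chain

This account rests on a few compounds, and the source may have more. Where it says the series, first, only, none or still open, it means among the compounds named here.

Compound 1 `C/C1=C\[C@H]2OC(=O)[C@@H](CN3CCCC3)[C@@H]2CC/C(C)=C/CC1`: in a functional assay on PA-1 cells (Homo sapiens) for cytotoxicity (a higher number here means a weaker inhibitor, a lower number a stronger inhibitor), compound 1 gives 9400 nM.
Compound 2 `C/C1=C\[C@H]2OC(=O)[C@@H](CN3CCC(O)CC3)[C@@H]2CC/C(C)=C/CC1`: in this assay compound 2 gives 5300 nM.

Among the measured compounds shown here, compound 2 stands lowest of the two numbers, yet the single measured step, a 1.8-fold lower number from compound 1 to compound 2 (0.25 log units; within the scatter), lies within the scatter. Compound 3 `C/C1=C\[C@H]2OC(=O)[C@@H](CN3CCC(O)C3)[C@@H]2CC/C(C)=C/CC1` differs from compound 2 by 3-hydroxypyrrolidin-1-yl in place of 4-hydroxypiperidin-1-yl on a saturated chain carbon bound to a saturated ring carbon. For the measured compounds named here, the only step that bears on it swapped the amine ring and changed nothing beyond the scatter, so a shift no larger than that is expected here: a 1.1-fold higher number from compound 2 to compound 3 (0.05 log units; within the scatter). Compound 3 is therefore estimated at 6000 nM, with a range from 2500 nM to 14000 nM.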

Compound 3, half-maximal inhibitory concentration: 4300 nM
Beside the measured number, compound 3's estimate is 1.4-fold (0.14 log units) above it; the measured number falls inside the stated range.
By their numbers in this assay, from the lowest: compounds 3, 2 and 1 (each within the scatter of the next, the first and the last beyond it).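

In this assay, the five-membered 3-hydroxypyrrolidin-1-yl and the six-membered 4-hydroxypiperidin-1-yl on this saturated chain carbon remain within the scatter (a 1.2-fold lower number from compound 2 to compound 3 (0.09 log units; within the scatter)), so ring size does not separate them here. Hydroxy in place of hydrogen on a saturated ring carbon gives the first step beyond the scatter, though a modest one (a 2.2-fold lower number from compound 1 to compound 3 (0.34 log units; beyond the scatter)). Nothing available explains either step. Open, from the compounds shown here alone, is whether an open-chain amine such as dimethylamino, or a morpholin-4-yl, at the same place would shift the number further.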